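Diazabicyclic amides: cyclobutyl against 2-methylcyclopropyl

This account rests on a few compounds, and the source may have more. Where it says the series, first, only, none or still open, it means among the compounds named here.

Compound 1 `O=C(C1CCC1)N1CC2CC(C1)N2` gives 370 nM in an assay on CHO cells for agonist activity at Neuronal acetylcholine receptor; alpha3/alpha6/beta2/beta3 (Homo sapiens), read by FLIPR and calcium flux; a higher number here means that more compound is needed for the effect, a lower number that less compound is needed.
Compound 2 `O=C(CC1C=CCC1)N1CC2CC(C1)N2` gives 21000 nM in this assay.

Compound 1 holds the lower of the two numbers; compound 2 sits a long way above it, beyond the scatter. Compound 3 `C[C@H]1C[C@H]1C(=O)N1CC2CC(C1)N2` is the next step from compound 1: 2-methylcyclopropyl in place of cyclobutyl on a carbonyl carbon. Within the data shown here, no pair differing in one place has been measured, so no step of this kind is known. A change that keeps the same atom count on the carbonyl carbon is expected to move the number little, if at all beyond the scatter, so the estimated step of a 1.2-fold lower number from compound 1 to compound 3 (0.09 log units; within the scatter) is small. For compound 3 the expected value in this assay is 300 nM, within 80 nM to 1200 nM.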

Compound 3, half-maximal effective concentration: 2000 nM
Compound 3: the middle estimate sits 6.7-fold (0.82 log units) below what was measured; measured number outside the range, above it.
By their numbers in this assay, from the lowest: compound 1; then compound 3; then compound 2.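

In this assay, among these compounds, the change to 2-methylcyclopropyl in place of cyclobutyl on a carbonyl carbon gives a 5.4-fold higher number from compound 1 to compound 3 (0.73 log units; beyond the scatter) and is the first one-place step. The carbon count of the group stays the same, so at this position the number responds to how those carbons are arranged, not only to how many there are. Nothing at hand explains the step.

Still open, from the compounds shown here alone, is whether the opposite stereoisomer of 2-methylcyclopropyl gives a similar number. Going by these compounds, it is also open whether a plain cyclopropyl or a cyclopentyl at this position would fall nearer to compound 1.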